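The source may hold more compounds than are shown below. What is called first, only, known or untested is meant among the compounds shown, and "the series" means these compounds.

Working notes on the series. The shared core, carried unchanged across compounds 1 to 3, is that of compound 1 `C[C@@H](Cn1ccc(-c2ccc(C#N)c(Cl)c2)n1)Nc1ccccc1`. In a functional assay on LNCaP cells (Homo sapiens) for antiproliferative activity, read by CCK-8 assay, with a stated time of 6 days (on this read-out higher numbers stand for weaker inhibition and lower numbers for stronger inhibition), compound 1 gives 710 nM. Compound 2 `C[C@@H](Cn1ccc(-c2ccc(C#N)c(Cl)c2)n1)Nc1cncnc1` replaces the phenyl on the amine nitrogen with pyrimidin-5-yl, and in this assay compound 2 gives 2070 nM; the step of a 2.9-fold higher number from compound 1 to compound 2 (0.46 log units; beyond the scatter) is the only one measured so far. On the numbers in hand compound 2 therefore stands as the higher of the two, with compound 1 the nearer and lower neighbour.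

Compound 3 `C[C@@H](Cn1ccc(-c2ccc(C#N)c(Cl)c2)n1)Nc1ncnc2nc[nH]c12` takes the next step from compound 2: a group of 9 heavy atoms (5 carbon, 4 nitrogen; one five-membered aromatic ring with 2 hetero atoms, one six-membered aromatic ring with 2 hetero atoms) in place of a group of 6 heavy atoms (4 carbon, 2 nitrogen; one six-membered aromatic ring with 2 hetero atoms), on an amine nitrogen. The entering group keeps a six-membered aromatic ring with two hetero atoms but fuses a five-membered aromatic ring with two hetero atoms onto it and brings one hydrogen-bond donor. For the measured compounds named here, no measured pair exchanges a single aromatic ring for a fused pair on this amine nitrogen, so the only bearing step is a 2.9-fold higher number from compound 1 to compound 2 (0.46 log units; beyond the scatter), which showed that swapping the aryl on this nitrogen moves the number by a modest amount and, there, upward. Further exchange of the aryl is expected to move this assay by a modest amount again, without a clear direction, so for compound 3 the step of a 1.2-fold higher number from compound 2 to compound 3 (0.08 log units; within the scatter) is estimated as small against the scatter. Compound 3 is accordingly expected at 2500 nM, within 800 nM to 8000 nM.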

Compound 3, half-maximal inhibitory concentration: 960 nM
Compound 3: the middle estimate sits 2.6-fold (0.42 log units) above what was measured, and the stated range covers the measured number.
By their numbers in this assay, from the lowest: compounds 1 and 3 (each within the scatter of the next); then compound 2.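

The aryl exchange on this amine nitrogen has no single direction: in this assay the fused group gives a 2.2-fold lower number from compound 2 to compound 3 (0.33 log units; beyond the scatter), which runs opposite to the earlier exchange of phenyl for pyrimidin-5-yl (a 2.9-fold higher number from compound 1 to compound 2 (0.46 log units; beyond the scatter)). Set against phenyl, the same fused group gives a 1.4-fold higher number from compound 1 to compound 3 (0.13 log units; within the scatter), so the larger group of 9 heavy atoms, with its hydrogen-bond donor, cannot be told apart from phenyl in this read-out, and the place on the amine nitrogen accepts both a single aromatic ring and a fused pair with numbers inside the scatter of each other. No measurement at hand bears on why the fused group and pyrimidin-5-yl differ.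

On these data alone, it remains open whether the hydrogen-bond donor of the entering group has any bearing on the number of compound 3, or whether the fused pair alone accounts for it. Also open, as far as these compounds go, is how a non-aromatic group on this amine nitrogen, such as cyclohexyl or a short alkyl chain, would stand against phenyl in this assay.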